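Swapping cyclopentyl for tert-butoxy on the amide carbonyl

This account rests on a few compounds, and the source may have more. Where it says the series, first, only, none or still open, it means among the compounds named here.

Compound 3 `Cc1cc(NC(=O)C2CCCC2)nn1Cc1cc(Cl)ccc1OCC(C)C` gives 25.1 nM in an assay on CHO-K1 cells for displacement of a labelled ligand from prostaglandin E2 receptor EP1 subtype (Homo sapiens) (a higher number here means a weaker inhibitor, a lower number a stronger inhibitor), the lowest number among the three measured compounds. Compound 1 `Cc1cc(C(N)=O)nn1Cc1cc(Cl)ccc1OCC(C)C` gives 126 nM and compound 2 `Cc1cc(C(=O)NN2CCCCC2)nn1Cc1cc(Cl)ccc1OCC(C)C` gives 200 nM in this assay; the steps of a 5.0-fold lower number from compound 1 to compound 3 (0.70 log units; beyond the scatter) and an 8.0-fold lower number from compound 2 to compound 3 (0.90 log units; beyond the scatter) both run downward toward the (cyclopentylcarbonyl)amino compound. Compound 4 `Cc1cc(NC(=O)OC(C)(C)C)nn1Cc1cc(Cl)ccc1OCC(C)C` keeps that arrangement except that (tert-butoxy in place of cyclopentyl on a carbonyl carbon), giving a (tert-butoxycarbonyl)amino group. Within the data shown here, no measured step touches this part of the molecule, so the change is untested here, and the two downward steps into compound 3 give the only guidance. The expectation for compound 4 is a step of a 1.6-fold higher number from compound 3 to compound 4 (0.20 log units; within the scatter) that stays within the scatter. The estimate for compound 4 is 40 nM, with a range from 12 nM to 130 nM.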

Compound 4, half-maximal inhibitory concentration: 31.6 nM
For compound 4 the middle estimate is 1.3-fold (0.10 log units) above the measured one; low and high end bracket the measured number.
By their numbers in this assay, from the lowest: compounds 3 and 4 (each within the scatter of the next); then compounds 1 and 2 (each within the scatter of the next).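

On this carbonyl carbon, tert-butoxy and cyclopentyl give numbers within the scatter of each other in this assay (a 1.3-fold higher number from compound 3 to compound 4 (0.10 log units; within the scatter)), so an open chain with an oxygen serves as well here as the carbon-only ring. The (tert-butoxycarbonyl)amino group also stays clearly ahead of the two carbamoyl-type groups (a 4.0-fold lower number from compound 1 to compound 4 (0.60 log units; beyond the scatter); a 6.3-fold lower number from compound 2 to compound 4 (0.80 log units; beyond the scatter)). No measurement shown here gives a reason for this result.

Still open, from the compounds shown here alone, is how a smaller methyl, a phenyl ring or a dimethylamino group on this carbonyl carbon would compare with compound 3 and compound 4.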